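This account rests on a few compounds, and the source may have more. Where it says the series, first, only, none or still open, it means among the compounds named here.

Compound 1 `CCn1c([C@@H](C)NS(=O)(=O)c2ccc(Cl)cc2)nc2cccc(Cl)c21` and compound 2 `CCn1c([C@@H](C)NS(=O)(=O)c2c(F)cc(F)cc2F)nc2ccc(C(F)(F)F)cc21` share a core and were tested in an ADME assay (liver) for metabolic stability, with Liver microsome (Homo sapiens) as the target, read by LC-MS, using microsomes and NADPH, with a stated time of 5 min, at 37 degrees C; a higher number here means faster removal of the compound, a lower number slower removal. Compound 1 reaches only a limit of the assay, > 100 mL.min-1.g-1, noted as the limit of > 100 mL.min-1.g-1 in this assay, at which 1 of the 2 values shown sits. Compound 2 gives 19 mL.min-1.g-1, the only plain number shown. Compound 3 `CCn1c([C@@H](C)NS(=O)(=O)c2cnc(NC(C)=O)s2)nc2ccc(C(F)(F)F)cc21` has not yet been measured in this assay; it differs from compound 2 by 2-acetamido-1,3-thiazol-5-yl in place of 2,4,6-trifluorophenyl on a sulfonyl sulfur. Within the data shown here, no step between two measured compounds is available to guide this change, so the expectation rests on compound 2 alone. A modest step from compound 2 to compound 3 of a 1.6-fold lower number from compound 2 to compound 3 (0.20 log units; within the scatter) toward slower removal is expected, within or near the usual scatter. Compound 3 is estimated at 12 mL.min-1.g-1, between 4 mL.min-1.g-1 and 40 mL.min-1.g-1.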

Compound 3, intrinsic clearance in microsomes: 15 mL.min-1.g-1
Compound 3: the middle estimate sits 1.3-fold (0.10 log units) below what was measured, and the stated range covers the measured number.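

On a sulfonyl sulfur, 2-acetamido-1,3-thiazol-5-yl and 2,4,6-trifluorophenyl cannot be told apart in this assay: the change gives a 1.3-fold lower number from compound 2 to compound 3 (0.10 log units; within the scatter). This holds even though the entering group brings a hydrogen-bond donor and hydrogen-bond acceptors that the leaving group lacks. Compound 1 differs from both compounds in more than one place, and its value is a limit, not a number: the limit of > 100 mL.min-1.g-1 in this assay, at which 1 of the 3 values shown sits.

Still open, as far as these compounds go, is how removal would respond if an amine or a carboxylic acid replaced the acetamido group on this ring.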